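This account rests on a few compounds, and the source may have more. Where it says the series, first, only, none or still open, it means among the compounds named here.

Values in a physicochemical assay for solubility, measured as kinetic solubility (a lower number here means a less soluble compound, a higher number a more soluble compound), for the series so far:
- compound 1 `Cc1cnc(NC(=O)c2cc(Oc3ncc(C(=O)N(C)C)cn3)c3cc(C)oc3c2)cn1` gives 485000 nM
- compound 2 `COC1CN(C(=O)c2cnc(Oc3cc(C(=O)Nc4cnccn4)cc4oc(C)cc34)cn2)C1` gives 158000 nM
- compound 3 `Cc1cc2c(Oc3cnc(C(=O)N4CC(C)(O)C4)cn3)cc(C(=O)Nc3cnccn3)cc2o1` gives 137000 nM

Compound 3 stands level with compound 2, within the scatter, and beyond the scatter under compound 1. Compound 4 `Cc1cc2c(Oc3cnc(C(=O)N(C)C)cn3)cc(C(=O)Nc3cnccn3)cc2o1` is still unmeasured. It differs from compound 3 in one place, with dimethylamino in place of 3-hydroxy-3-methylazetidin-1-yl on a carbonyl carbon.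

Within the data shown here, only one measured step changes this same amide group, namely a 1.2-fold lower number from compound 2 to compound 3 (0.06 log units; within the scatter) and it stays within the scatter. That step exchanges one azetidine for another, so it does not test the loss of the ring. Compound 1, at 485000 nM in this assay, also carries dimethylamino on a carbonyl carbon, but it differs from compound 4 elsewhere in the structure, so it gives only a weak upward hint. Among the measured compounds shown here, no measured pair isolates this change.

A small upward move that stays within the scatter is therefore expected, estimated as a 1.5-fold higher number from compound 3 to compound 4 (0.16 log units; within the scatter) in this assay for this pair. For compound 4 the estimated value is 200000 nM with an expected range from 90000 nM to 450000 nM in this measurement.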

Compound 4, solubility: 30000 nM
Estimate against measurement, compound 4: 6.7-fold (0.82 log units) above, outside the stated range (below it).
By their numbers in this assay, from the lowest: compound 4; then compounds 3 and 2 (each within the scatter of the next); then compound 1.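

In this assay, among these compounds, this amide position now shows a response that the earlier compounds did not, with a 4.6-fold lower number from compound 3 to compound 4 (0.66 log units; beyond the scatter) and a 5.3-fold lower number from compound 2 to compound 4 (0.72 log units; beyond the scatter). The only earlier change here, a 1.2-fold lower number from compound 2 to compound 3 (0.06 log units; within the scatter), exchanged one azetidine for another, so the two azetidine amides stand level, whether the ring carries 3-methoxy or 3-hydroxy-3-methyl, and among these three compounds only the open dimethylamino group on the carbonyl carbon falls away from them. No measurement shown bears on why the number drops with this change.

Open, from the compounds shown here alone, is whether the drop follows the loss of the four-membered ring or the loss of the substituents on it: an unsubstituted azetidin-1-yl amide would separate the two, as would an open amide carrying a hydroxyethyl chain. Also open is how far the result holds on another core, since the other dimethylamino amide, compound 1 at 485000 nM, differs from compound 4 elsewhere in the structure and has no azetidine partner among the compounds shown.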